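This account rests on a few compounds, and the source may have more. Where it says the series, first, only, none or still open, it means among the compounds named here.

In a functional assay on HeLa cells (Homo sapiens) for inhibition, read by MTT assay, with a stated time of 72 h (a higher number here means a weaker inhibitor, a lower number a stronger inhibitor), three compounds have been measured so far:
compound 1 `COc1cc(NC(C)CCCNC(=O)Nc2cccc(F)c2)c2ncccc2c1` gives 18000 nM;
compound 2 `COc1cc(NC(C)CCCNC(=O)Nc2cccc(Cl)c2)c2ncccc2c1` gives 17000 nM;
compound 3 `COc1cc(NC(C)CCCNC(=O)NNC(=O)Nc2ccc(F)cc2)c2ncccc2c1` reaches only a limit of the assay, >= 250000 nM, and not a number.

Compound 1 and compound 2 share a core and differ by chloro in place of fluoro on an aromatic carbon; the step between them is a 1.1-fold lower number from compound 1 to compound 2 (0.02 log units; within the scatter). Compound 3 differs from compound 1 by ((4-fluorophenyl)carbamoyl)amino in place of 3-fluorophenyl on an amide-type nitrogen, and that change brings an at least 13-fold higher number from compound 1 to compound 3 (1.14 log units; beyond the scatter); from compound 2 the corresponding step is an at least 14-fold higher number from compound 2 to compound 3 (1.16 log units; beyond the scatter). Among the compounds with values here, the only evidence bearing on these measured steps is that one of the three values sits at the limit of >= 250000 nM in this assay, at which 1 of the 3 values shown sits.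

Compound 4 `COc1cc(NC(C)CCCNC(=O)NNC(=O)Nc2ccc(Cl)cc2)c2ncccc2c1` has not yet been measured in this assay. It differs from compound 3 by chloro in place of fluoro on an aromatic carbon, which is the same kind of change as that from compound 1 to compound 2, though the place is not the same: in the earlier pair the change sits meta to a large group, in the new pair para to a large group. The change occurs in these two pairs among the compounds shown. The earlier step was within the scatter, and compound 3 already stands at the limit, so compound 4 is expected to move by about a number no higher from compound 3 to compound 4 (the limit leaves the size open) and most likely to reach the same limit. Compound 4 is estimated at 250000 nM, expected between 120000 nM and 500000 nM.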

Compound 4, half-maximal inhibitory concentration: 120000 nM
Estimate against measurement, compound 4: 2.1-fold (0.32 log units) above; the measured number falls inside the stated range.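

In this assay, chloro in place of fluoro on an aromatic carbon can be followed on two cores, and the two results can be set together: the same change on two cores in this assay, a 1.1-fold lower number (0.02 log units; within the scatter) from compound 1 to compound 2 and an at least 2.0-fold lower number (0.31 log units; beyond the scatter) from compound 3 to compound 4; the limit leaves it open whether they differ. Of the step on the second core, an at least 2.0-fold lower number from compound 3 to compound 4 (0.31 log units; beyond the scatter), only a smallest possible size is known, for compound 3 stands at a limit and not at a number: the limit of >= 250000 nM in this assay, at which 1 of the 4 values shown sits. Compound 4, with its ((4-chlorophenyl)carbamoyl)amino group, still lies apart from the two simpler ureas, with a 7.1-fold higher number from compound 2 to compound 4 (0.85 log units; beyond the scatter) and a 6.7-fold higher number from compound 1 to compound 4 (0.82 log units; beyond the scatter), but the data do not show whether the size of the halogen change carries from one core to the other.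

The compounds shown leave open how bromo, methyl or trifluoromethyl would behave on the same aromatic carbon of either core, and what an amine or a carboxylic acid would do there. They also leave open whether the halogen change would give a similar step with a shorter or longer chain in place of the one shared by all four compounds.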